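Swapping Nitro for Tert-Butyl on a Shared Core

The source may report more compounds than this note shows. Statements on the series, on what has been measured and on what is new or still open speak of the compounds shown alone.

In a functional assay on T47D cells (Homo sapiens) for cytotoxicity, read by MTT assay, with a stated time of 96 h (a lower number here means a stronger inhibitor, a higher number a weaker inhibitor), compound 1 (`N=C(N)c1ccc(-c2ccc(-c3ccc([N+](=O)[O-])cc3)o2)cc1`) gives 3800 nM and compound 2 (`N=C(N)c1ccc(-c2ccc(-c3cccc([N+](=O)[O-])c3)o2)cc1`) gives 3300 nM as its reading. For the measured compounds named here, these two numbers lie within the usual scatter of repeated measurements, so compound 1 stands level with the only other measured compound and neither can be ranked. Compound 3 (`CC(C)(C)c1ccc(-c2ccc(-c3ccc(C(=N)N)cc3)o2)cc1`) keeps the core of compound 1 but has tert-butyl in place of nitro on an aromatic carbon, and tert-butyl in place of nitro on an aromatic carbon sums up that swap. Going by the values given here, no measured pair shows what this swap does, so the direction is uncertain. In this assay no step beyond the scatter is expected, with a slight lean toward a lower number. The estimated change is a 1.5-fold lower number from compound 1 to compound 3 (0.18 log units; within the scatter) at the middle of the range. Compound 3 is expected near 2500 nM with a range from 700 nM to 9000 nM in this estimate.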

Compound 3, half-maximal inhibitory concentration: 3600 nM
Estimate against measurement, compound 3: 1.4-fold (0.16 log units) below; the range from low to high includes it.
By their numbers in this assay, from the lowest: compounds 2, 3 and 1 (each within the scatter of the next).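

In this assay, putting tert-butyl in place of nitro on the aromatic carbon gives a 1.1-fold lower number from compound 1 to compound 3 (0.02 log units; within the scatter), a step that lies within the usual scatter. At this position, para to a large group, an all-carbon group with no hydrogen-bond acceptors can therefore take the place of one that holds nitrogen and oxygen, and compound 1 and compound 3 still stand level. No supporting measurement is available to explain why these two different groups give such similar readings.

As far as these compounds go, it remains open whether an amine, a carboxylic acid or a longer chain at this position would also stand level with these compounds or move the reading beyond the scatter. This single step also cannot show whether the same swap would read alike on another aromatic carbon of the ring.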